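Nitro in place of carbamoyl: expected shift

The source may hold more compounds than are shown below. What is called first, only, known or untested is meant among the compounds shown, and "the series" means these compounds.

Compound 3 `COc1ccc(/C=C2\c3cc(OC)c(OC)c(OC)c3CC[C@H]2O)cc1C(N)=O` gives 1920 nM in a functional assay on SK-OV-3 cells (Homo sapiens) for inhibition, read by MTT assay (on this read-out higher numbers stand for weaker inhibition and lower numbers for stronger inhibition), and stands with compound 2 `COc1ccc(/C=C2\c3cc(OC)c(OC)c(OC)c3CC[C@H]2O)cc1O` at 1590 nM since a 1.2-fold higher number from compound 2 to compound 3 (0.08 log units; within the scatter) stays inside the scatter. Compound 1 `COc1ccc(/C=C2\c3cc(OC)c(OC)c(OC)c3CC[C@H]2O)cc1C#N` at 600 nM is clear of both, with a 2.7-fold higher number from compound 1 to compound 2 (0.42 log units; beyond the scatter) and a 3.2-fold higher number from compound 1 to compound 3 (0.51 log units; beyond the scatter) as modest steps. Compound 4 `COc1ccc(/C=C2\c3cc(OC)c(OC)c(OC)c3CC[C@H]2O)cc1[N+](=O)[O-]` follows from compound 3 by nitro in place of carbamoyl on an aromatic carbon as nitro in place of carbamoyl on an aromatic carbon. Among the measured compounds shown here, no measured step involves nitro, so the only guide is the modest size of a 3.2-fold higher number from compound 1 to compound 3 (0.51 log units; beyond the scatter) on this carbon. The expected change is a 2.1-fold lower number from compound 3 to compound 4 (0.33 log units; beyond the scatter) as a modest step to a lower number in this assay with no larger move foreseen. In this assay compound 4 is estimated at 900 nM with 400 nM and 2000 nM as the ends of its range.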

Compound 4, half-maximal inhibitory concentration: > 10000 nM
Compound 4: no number, only a limit; the forecaster's own chance of this, stated with the estimate: 2%; at least 11-fold (1.04 log units) between middle value and limit.
By their numbers in this assay, from the lowest: compound 1; then compounds 2 and 3 (each within the scatter of the next). At a limit, above all of these: compound 4.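

In this assay compound 4 gives no number, only a limit: the limit of > 10000 nM in this assay, at which 1 of the 4 values shown sits.

On this aromatic carbon, ortho to a methoxy group, the change to nitro is a far larger move than the modest steps among the earlier groups: an at least 5.2-fold higher number from compound 3 to compound 4 (0.71 log units; beyond the scatter), an at least 6.2-fold higher number from compound 2 to compound 4 (0.79 log units; beyond the scatter), and an at least 16-fold higher number from compound 1 to compound 4 (1.22 log units; beyond the scatter). Carbamoyl and nitro each have 3 heavy atoms, so this position separates groups of equal heavy-atom count.

On these data alone, whether this loss of inhibition is particular to nitro stays open. An amine or a carboxylic acid on the same carbon would show whether other groups share it.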